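Quinoline amide series: trifluoromethyl for ethyl at low activity

This account rests on a few compounds, and the source may have more. Where it says the series, first, only, none or still open, it means among the compounds named here.

Measured compounds:
compound 1 `CCc1ccc2nc(C(=O)Nc3c(F)cc(-c4cccc(F)c4)cc3F)c(C)c(O)c2c1`, 11.2%
compound 2 `CCOc1ccc2nc(C(=O)Nc3c(F)cc(-c4cccc(F)c4)cc3F)c(C)c(O)c2c1`, 0.01%
compound 3 `CCc1ccc2nc(C(=O)Nc3c(F)cc(-c4cccc(F)c4)cc3F)c(C)c(C(=O)O)c2c1`, 0.68%

In a functional assay on Hep 3B2 cells (Homo sapiens) for antiproliferative activity, read by MTT assay, with a stated time of 24 h, tested at 0.14 ug/mL (a higher number here means a stronger effect of the compound at the concentration tested, a lower number a weaker effect), compound 1 gives 11.2%, compound 2 gives 0.01% and compound 3 gives 0.68%. Compound 3 stands second highest of the three numbers; its nearest neighbour is compound 2, lower by a margin within the scatter, and its furthest is compound 1, higher beyond the scatter.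

Two steps are known. Going from compound 1 to compound 2, a number 11.2 percentage points lower from compound 1 to compound 2 (beyond the scatter). Going from compound 1 to compound 3, a number 10.5 percentage points lower from compound 1 to compound 3 (beyond the scatter).

Compound 4 `Cc1c(C(=O)Nc2c(F)cc(-c3cccc(F)c3)cc2F)nc2ccc(C(F)(F)F)cc2c1C(=O)O` is the next compound. Its change from compound 3 is trifluoromethyl in place of ethyl on an aromatic carbon. The step from compound 1 to compound 2 is the one that touches the same place, an exchange of ethyl for another group on that aromatic carbon, and it gave a modest drop; the step from compound 1 to compound 3 tells nothing about this place. Compound 3 already sits near the floor of this assay, so little room for a further drop remains. For compound 4 the expected step in this assay is a number 1.3 percentage points higher from compound 3 to compound 4 (within the scatter), no change beyond the scatter. Compound 4 is therefore estimated at 2%, with a range from 0% to 12%.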

Compound 4, a percentage reported as inhibition, at one concentration (the size of the read-out at that concentration, not a potency): 2.13%
For compound 4 the middle estimate is 0.1 percentage points below the measured one; measured number inside the range.
By their numbers in this assay, from the lowest: compounds 2, 3, 4 and 1 (each within the scatter of the next, the first and the last beyond it).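

In this assay, the new step reads a number 1.5 percentage points higher from compound 3 to compound 4 (within the scatter), so with carboxy on the shared core, trifluoromethyl in place of ethyl on this aromatic carbon gives no change beyond the scatter. This is a second reading at the same place, and it differs from the earlier one, a number 11.2 percentage points lower from compound 1 to compound 2 (beyond the scatter), in both the entering group and the background, since that step has hydroxy on the core and ethoxy as the entering group; the two steps therefore cannot be set against each other as a ranking of trifluoromethyl and ethoxy. No measurement among the data bears on why the new step comes out as it does.

The compounds shown leave open how trifluoromethyl reads with hydroxy in place of carboxy, the single-place comparison that would set it directly against compound 1 and show whether the low numbers at this position depend on the carboxy background. Also open, as far as these compounds go, is whether a chlorine, an amine or a longer chain on this aromatic carbon would give a number clearly different from those of the ethyl and trifluoromethyl pair.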